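A few compounds are considered here, and "the series" means these few. Any claim that something is new, unique, unknown or untested is made for them only; others in the source may bear on it.

Of the compounds shown here, three have so far been tested in a toxicity assay on THP-1 cells (Homo sapiens) for inhibition; a lower number here means that less compound is tolerated, a higher number that more compound is tolerated. Compound 1 `COc1ccc2nc(NC(=O)c3ccc(F)cc3)n(C)c2c1` gives > 100000 nM, which is a limit of the assay rather than a measured number. Compound 2 `COc1ccc(-c2cnc(NC(=O)c3cccnc3)n2C)cc1` likewise gives > 100000 nM, again a limit of the assay. Compound 3 `Cn1c(-c2ccccc2)cnc1NC(=O)c1ncc[nH]1` gives > 100000 nM, also a limit. Compound 2 therefore stands exactly where every other measured compound stands, at the limit of > 100000 nM in this assay, at which 3 of the 3 values shown sit. Among the measured compounds shown here, no pair of measured compounds differs in one place only, so no measured step is available to lean on.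

Compound 4 `COc1ccc(-c2cnc(NC(=O)c3ccc(F)cc3)n2C)cc1` has not yet been measured. It differs from compound 2 in a single place: 4-fluorophenyl in place of pyridin-3-yl on a carbonyl carbon. With all three values resting on the same limit (the limit of > 100000 nM in this assay, at which 3 of the 3 values shown sit), the step of a number no higher from compound 2 to compound 4 (the limit leaves the size open) in this assay is expected to be none beyond the usual scatter. For compound 4 the half-maximal cytotoxic concentration in this assay is estimated at 100000 nM, with a range from 40000 nM to 300000 nM, most probably reported once more only as a limit.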

Compound 4, half-maximal cytotoxic concentration: >= 50000 nM
Compound 4 was reported as a limit; the forecaster's own chance of this, stated with the estimate: 85%; the middle value lies beyond the limit too.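

Among the compounds shown here, compound 2 and compound 4 are both reported in this assay only as limits and not as measured numbers, so no step between them can be read. The compounds shown leave open at what concentration, if any, each of them becomes toxic to these cells.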